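The source may hold more compounds than are shown below. What is called first, only, known or untested is meant among the compounds shown, and "the series" means these compounds.

Among the measured compounds shown here, in an ADME assay on HEK293 cells (Homo sapiens) for cytotoxicity, read by MTT assay, with a stated time of 24 h (on this read-out higher numbers stand for weaker inhibition and lower numbers for stronger inhibition), three compounds on one shared core have numbers so far. Compound 1 `CN(C)CCCNc1nc2cc([N+](=O)[O-])ccc2nc1NCc1ccc(F)cc1` gives 4.28 ug/mL and compound 2 `CN(C)CCCNc1nc2cc([N+](=O)[O-])ccc2nc1NCc1ccccc1Br` gives 51.9 ug/mL while compound 3 `CN(C)CCCNc1nc2cc([N+](=O)[O-])ccc2nc1NCc1cccc(C(F)(F)F)c1` gives 7.99 ug/mL as the second highest of the three. Its place is fixed by a 1.9-fold higher number from compound 1 to compound 3 (0.27 log units; within the scatter) on one side and by a 6.5-fold lower number from compound 2 to compound 3 (0.81 log units; beyond the scatter) on the other. Compound 4 `CN(C)CCCNc1nc2cc([N+](=O)[O-])ccc2nc1NCc1cccc(Br)c1` carries the change bromo in place of trifluoromethyl on an aromatic carbon that reads as bromo in place of trifluoromethyl on an aromatic carbon. For the measured compounds named here, no measured step makes this exchange at one place. Going by the values given here, compound 2 is the only measured bromo compound, and it stands apart through a 12-fold higher number from compound 1 to compound 2 (1.08 log units; beyond the scatter) as a large step, but its bromo is not placed as in compound 4. The evidence is therefore indirect, and no step beyond the scatter is expected in this assay for this change, with some room left upward. The value estimated for compound 4 is 9 ug/mL with an expected range from 3.5 ug/mL to 25 ug/mL around it. This estimate means a 1.1-fold higher number from compound 3 to compound 4 (0.05 log units; within the scatter) as the expected step.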

Compound 4, half-maximal inhibitory concentration: 3.66 ug/mL
For compound 4 the middle estimate is 2.5-fold (0.39 log units) above the measured one; the measured number falls inside the stated range.
By their numbers in this assay, from the lowest: compounds 4, 1 and 3 (each within the scatter of the next, the first and the last beyond it); then compound 2.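

In this assay, among the compounds shown here, the exchange of trifluoromethyl for bromo at one place gives a 2.2-fold lower number from compound 3 to compound 4 (0.34 log units; beyond the scatter) and so shows, for the first time, a modest step beyond the scatter for this change at this position. The step of a 14-fold lower number from compound 2 to compound 4 (1.15 log units; beyond the scatter) is large and shows that bromo alone does not bring the high number of compound 2, since the 3-bromophenyl group does not share it. With a 1.2-fold lower number from compound 1 to compound 4 (0.07 log units; within the scatter) as the remaining step, the 3-bromophenyl and 4-fluorophenyl groups cannot be told apart in this read-out. Nothing available accounts for these differences. The compounds shown leave open whether a chloro or a methoxy group in the same place would follow bromo or trifluoromethyl. They also leave open whether the high number of compound 2 is particular to the 2-bromophenyl group.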